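A 3,4-difluorophenyl step from compound 3

This account rests on a few compounds, and the source may have more. Where it says the series, first, only, none or still open, it means among the compounds named here.

Three compounds make up the record so far, and only two of them carry a reading. In an ADME assay on HepG2 cells (Homo sapiens) for cytotoxicity, read by XTT assay, with a stated time of 2 days (on this read-out lower numbers stand for higher toxicity in this test and higher numbers for lower toxicity in this test), compound 1 `Cc1c(C(=O)Nc2ccccc2)sc(N)c1C(N)=S` gives > 100000 nM, which is a limit of the assay and not a number. Compound 2 `Cc1c(C(=O)Nc2cc(F)c(F)c(Cl)c2)sc(N)c1C#N` has no usable reading, its entry in this assay being "not determined" (no result reported). In this assay compound 3 `Cc1c(C(=O)Nc2ccccc2)sc(N)c1C(=O)Nc1ccccc1` gives > 100000 nM, again a limit and not a number. Compound 3 therefore stands at the limit of > 100000 nM in this assay, at which 2 of the 3 values shown sit, without an exact figure of its own.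

Compound 4 `Cc1c(C(=O)Nc2ccccc2)sc(N)c1C(=O)Nc1ccc(F)c(F)c1` keeps the rest of compound 3 and changes one group: 3,4-difluorophenyl in place of phenyl on an amide-type nitrogen. In short, it carries 3,4-difluorophenyl in place of phenyl on an amide-type nitrogen. Going by the values given here, no measured pair in this small set shows what such a change does, so no step beyond the usual scatter is expected in this assay, and neither direction is favoured. The expectation rests on compound 3, whose limit is > 100000 nM. The estimated change is a number no higher from compound 3 to compound 4 (the limit leaves the size open). Compound 4 is expected to read about 100000 nM, with an estimated range from 35000 nM to 200000 nM.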

Compound 4, half-maximal cytotoxic concentration: 40000 nM
For compound 4 the middle estimate is 2.5-fold (0.40 log units) above the measured one; the measured number falls inside the stated range.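

In this assay, 3,4-difluorophenyl in place of phenyl on an amide-type nitrogen gives an at least 2.5-fold lower number from compound 3 to compound 4 (0.39 log units; beyond the scatter), a shift towards higher toxicity in this test. The earlier compounds shown here could not show this, as neither of their readings was an exact number, whereas compound 4 gives the first exact figure in the set and shows that this place on the molecule can move the read-out. The size of the step remains open at its upper end, and compound 4 has no exact reading among its neighbours to be set against: the limit of > 100000 nM in this assay, at which 2 of the 4 values shown sit.

The compounds shown leave open whether both fluorines are needed for the step, or whether a lone fluorine, a chlorine or a methoxy group on that phenyl ring would lower the number to the same degree. They also do not tell how a ring-borne amine or carboxylic acid at this place would read, or whether a saturated group such as cyclohexyl in place of the phenyl would stay at the limit of the assay.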